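Heteroaryl ketone variation in an HDAC8 inhibitor series

The compounds below may be only part of what the source reports. "The series", "measured", "known", "first", "only" and "open" are said of these compounds alone.

Of the compounds shown here, two have been measured in an assay for inhibition of histone deacetylase 8 (Homo sapiens), read by fluorescence, with stated times of 3 h and 60 min; a higher number here means a weaker inhibitor, a lower number a stronger inhibitor. Compound 1 `N[C@@H](CCCCCC(=O)c1ccon1)c1ncc(-c2ccccc2F)[nH]1` gives 280 nM. Compound 2 `CN1CCC(C(=O)N[C@@H](CCCCCC(=O)c2nccs2)c2ncc(-c3ccc(F)cc3)[nH]2)CC1` gives 380 nM in this assay, the higher of the two numbers, though its gap to compound 1 lies within the scatter. Compound 3 `Cc1coc(C(=O)CCCCC[C@H](NC(=O)C2CCN(C)CC2)c2ncc(-c3ccc(F)cc3)[nH]2)n1` differs from compound 2 by 4-methyl-1,3-oxazol-2-yl in place of 1,3-thiazol-2-yl on a carbonyl carbon. Going by the values given here, no step between measured compounds addresses this change, so the author expects compound 3 to be roughly level with compound 2, with no step beyond the scatter, written as a 1.1-fold higher number from compound 2 to compound 3 (0.02 log units; within the scatter). Compound 3 is therefore estimated at 400 nM, between 150 nM and 1100 nM.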

Compound 3, half-maximal inhibitory concentration: 8000 nM
For compound 3 the middle estimate is 20-fold (1.30 log units) below the measured one, outside the stated range (above it).
By their numbers in this assay, from the lowest: compounds 1 and 2 (each within the scatter of the next); then compound 3.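

In this assay, the group on the carbonyl carbon proves highly sensitive to change: 4-methyl-1,3-oxazol-2-yl in place of 1,3-thiazol-2-yl brings a 21-fold higher number from compound 2 to compound 3 (1.32 log units; beyond the scatter). Both groups are a five-membered aromatic ring with the same counts of hydrogen-bond donors and acceptors, so these shared counts do not preserve the value here. No measurement at hand explains the step.

The swap changes the ring and adds a methyl at once, so the two changes cannot be separated. A 1,3-oxazol-2-yl without the methyl, or a 4-methyl-1,3-thiazol-2-yl, would divide the step between them.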